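Swapping chloro for fluoro on compound 1

A few compounds are considered here, and "the series" means these few. Any claim that something is new, unique, unknown or untested is made for them only; others in the source may bear on it.

Among the compounds with values here, compound 1, with the structure `C=CCn1c(=O)/c(=C\c2cccc(Cl)c2)[nH]c(=O)/c1=C\c1ccccc1OC`, is the one compound in this set with a numerical result. In a functional assay on BGC-823 cells (Homo sapiens) for cytotoxicity, read by CCK-8 assay, with a stated time of 72 h (on this read-out lower numbers stand for stronger inhibition and higher numbers for weaker inhibition), compound 1 gives 4600 nM. The two other measured compounds carry no number: compound 2, `COc1ccccc1/C=c1/[nH]c(=O)/c(=C\c2ccccc2OC)n(C)c1=O`, is reported in this assay as "not active" (no number reported), and compound 3, `COc1ccccc1/C=c1/[nH]c(=O)/c(=C\c2cccc(Cl)c2Cl)[nH]c1=O`, is likewise reported as "not active" (no number reported). Within the data shown here, since neither of those has a figure, compound 1 is simply the only entry with a number, and no step between measured compounds can be drawn from it.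

The unmeasured compound 4, `C=CCn1c(=O)/c(=C\c2cccc(F)c2)[nH]c(=O)/c1=C\c1ccccc1OC`, differs from compound 1 in one place: fluoro in place of chloro on an aromatic carbon. Nothing in this set tells how such a swap plays out here, so the expected step is a small one, within or only slightly beyond the scatter, leaning toward weaker inhibition. The step from compound 1 to compound 4 is expected to read a 1.4-fold higher number from compound 1 to compound 4 (0.15 log units; within the scatter). Compound 4 is therefore estimated at 6500 nM, within a range of 2500 nM to 16000 nM.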

Compound 4, half-maximal inhibitory concentration: 5600 nM
The estimate for compound 4 lay 1.2-fold (0.06 log units) above the measured number; the measured number falls inside the stated range.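

Going from 3-chlorophenyl to 3-fluorophenyl gives a 1.2-fold higher number from compound 1 to compound 4 (0.09 log units; within the scatter) in this assay, so this is the first pair in the set with a number at both ends. At this place on the ring, the two halogens cannot be told apart in this read-out, and the fluoro analogue stays in the same range as the chloro parent. Nothing measured here bears on why the two read alike.

Both groups are single halogen atoms, so this one swap says little about how far the position can be pushed. A hydrogen in their place, or something quite different such as an amine, a carboxylic acid or a longer chain, could show whether a substituent here matters at all.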